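Amine swap on the hydroxypiperidine series

The source may report more compounds than this note shows. Statements on the series, on what has been measured and on what is new or still open speak of the compounds shown alone.

Compound 1 `CCNC(=O)c1nnn(-c2cc(C(C)C)c(O)cc2O)c1-c1ccc(CN2CCCC(O)C2)cc1` (62 nM)
Compound 2 `CCNC(=O)c1nnn(-c2cc(C(C)C)c(O)cc2O)c1-c1ccc(CN2CCC[C@@H](O)C2)cc1` (52 nM)

In a functional assay on NCI-H460 cells (Homo sapiens) for inhibition, read by sulforhodamine B assay, with a stated time of 72 h (on this read-out higher numbers stand for weaker inhibition and lower numbers for stronger inhibition), compound 2 reads 52 nM and stands level with compound 1, the two differing only in a drawn configuration (a 1.2-fold lower number from compound 1 to compound 2 (0.08 log units; within the scatter)). Compound 3 `CCNC(=O)c1nnn(-c2cc(C(C)C)c(O)cc2O)c1-c1ccc(CN(CC)CC)cc1` carries diethylamino in place of 3-hydroxypiperidin-1-yl on a saturated chain carbon bound to an aromatic carbon. Among the compounds with values here, the one measured step leaves this group in place, so it gives no size for the change. Starting from compound 2 at 52 nM no direction can be argued, and a step within the scatter is expected, with a wide margin. The estimated step is a 1.2-fold higher number from compound 2 to compound 3 (0.06 log units; within the scatter) on this reasoning. Compound 3 is expected at 60 nM with a range from 20 nM to 180 nM on this estimate.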

Compound 3, half-maximal inhibitory concentration: 11 nM
Beside the measured number, compound 3's estimate is 5.5-fold (0.74 log units) above it, and the stated range ends above it.
By their numbers in this assay, from the lowest: compound 3; then compounds 2 and 1 (each within the scatter of the next).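

The amine on the saturated chain carbon bound to an aromatic carbon moves the number in this assay: diethylamino in place of 3-hydroxypiperidin-1-yl gives a 4.7-fold lower number from compound 2 to compound 3 (0.67 log units; beyond the scatter), and likewise a 5.6-fold lower number from compound 1 to compound 3 (0.75 log units; beyond the scatter). The ring, its hydroxyl and its stereocentre are thus not required at this position for activity on this read-out. Nothing at hand accounts for the size of these steps.

On these data alone, the change removes ring, hydroxyl and stereocentre together, and which of them carries the step stays open. Unsubstituted piperidin-1-yl or dimethylamino at the same place would separate these contributions.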